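Pyridyl substituent and maximal response in a thiazole acetic acid series

The source may hold more compounds than are shown below. What is called first, only, known or untested is meant among the compounds shown, and "the series" means these compounds.

Compound 1, `O=C(O)Cc1sc(C(c2ccc(F)cc2)c2ccc(F)cc2)nc1-c1ccnc(N2CCCC2)c1`, gives 80% in an in vitro functional assay on HEK285-7 cells for antagonist activity at prostaglandin D2 receptor 2 (Homo sapiens), read by BRET and beta-arrestin recruitment; on this read-out lower numbers stand for smaller maximal responses and higher numbers for larger maximal responses.
Compound 2, `O=C(O)Cc1sc(C(c2ccc(F)cc2)c2ccc(F)cc2)nc1-c1ccnc(Cl)c1`, gives 80% in this assay.
Compound 3, `Nc1cc(-c2nc(C(c3ccc(F)cc3)c3ccc(F)cc3)sc2CC(=O)O)cc(F)n1`, gives 30% in this assay.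

Compound 3 stands lowest of the three numbers. The step of a number 50 percentage points lower from compound 1 to compound 3 (beyond the scatter) and the step of a number 50 percentage points lower from compound 2 to compound 3 (beyond the scatter) are both large, whereas no change at the digits printed from compound 1 to compound 2 (within the scatter). Compound 4, `O=C(O)Cc1sc(C(c2ccc(F)cc2)c2ccc(F)cc2)nc1-c1cc(F)nc(F)c1`, is not yet measured; the change from compound 3 is fluoro in place of amino on an aromatic carbon. Both large steps bear on this: each one brought in the 2-amino-6-fluoropyridin-4-yl group and lowered the response. Taking the amino away again, toward a halogen-bearing pyridyl as in compound 2, is expected to move the number back upward, though only part of the way, so the step of a number 30 percentage points higher from compound 3 to compound 4 (beyond the scatter) is expected. For compound 4 the estimate in this assay is 60%, within 35% to 85%.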

Compound 4, largest response reached (reported as efficacy), in percent of the reference or control that the assay uses: 80%
Estimate against measurement, compound 4: 20 percentage points below; measured number inside the range.
By their numbers in this assay, from the lowest: compound 3; then compounds 1, 2 and 4 (each within the scatter of the next).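

In this assay fluoro in place of amino gives a number 50 percentage points higher from compound 3 to compound 4 (beyond the scatter), so within this pair the low response goes with the amino group and not with the fluoro group that stays. The 2,6-difluoropyridin-4-yl group sits level with the other two pyridyl groups, with no change at the digits printed from compound 2 to compound 4 (within the scatter) and no change at the digits printed from compound 1 to compound 4 (within the scatter). No measurement to hand accounts for the gap between amino and fluoro here.

Open, going by these compounds, is whether the 2-aminopyridin-4-yl group, lacking the fluoro group, also gives a low response. Also open, on these data alone, is whether methylamino or hydroxyl in place of amino does the same.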